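Acetyl in place of tert-butyl: what to expect

This account rests on a few compounds, and the source may have more. Where it says the series, first, only, none or still open, it means among the compounds named here.

Compound 1 `CN1CCN(c2nc3cc(C(C)(C)C)ccc3o2)CC1` carries a tert-butyl group on the shared core. In a functional assay on ileum (strain Hartley) for agonist activity at 5-hydroxytryptamine receptor 3A (Cavia porcellus) (a higher number here means a more potent compound, by a factor of ten per unit of this negative logarithm, a lower number a less potent compound), compound 1 gives < 4, which is a limit of the assay and not a number. Within the data shown here, the only evidence of this kind so far is the limit of < 4 in this assay, at which 1 of the 2 values shown sits. Compound 2 `CCc1cccc2nc(N3CCN(C)CC3)oc12` bears an ethyl group at another place on the same core. In this assay compound 2 gives 5.48, a number rather than a limit. Among the measured compounds shown here, no step between these two measured compounds is counted, so their values are set side by side and nothing more is read from them.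

Compound 3 `CC(=O)c1ccc2oc(N3CCN(C)CC3)nc2c1` has not yet been measured. It differs from compound 1 in one place: acetyl in place of tert-butyl on an aromatic carbon. For the measured compounds named here, no measured step bears directly on this change, so the expectation rests on the two values above alone. The step from compound 1 to compound 3 is estimated at a number at least 0.50 log units higher from compound 1 to compound 3 (beyond the scatter), upward from the limit but small enough that it may not clear the usual scatter. Compound 3 is expected at 4.5, within 3.8 to 5.4.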

Compound 3, negative logarithm of the half-maximal effective concentration: < 4
Compound 3: no number, only a limit; the forecaster's own chance of this, stated with the estimate: 30%; middle value at least 0.50 log units away from the limit.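

In this assay, among these compounds, compound 1 and compound 3 each give only a limit of the assay and not a number, so no step between them can be read. The evidence so far amounts to this: the limit of < 4 in this assay, at which 2 of the 3 values shown sit. The compounds shown leave open whether acetyl and tert-butyl on this aromatic carbon differ at all in this assay.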